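Quinoline-oxadiazole ureas: notes toward compound 4

The source may hold more compounds than are shown below. What is called first, only, known or untested is meant among the compounds shown, and "the series" means these compounds.

Measured so far in a functional assay on Shh Light II cells (Mus musculus) for inhibition, read by a luciferase reporter; on this read-out lower numbers stand for stronger inhibition and higher numbers for weaker inhibition:
- compound 1 `O=C(NC1CCCCC1)N1CCN(c2nc(-c3ccc4ccccc4n3)no2)CC1` gives 53 nM
- compound 2 `CC(C)c1ccccc1NC(=O)N1CCC(c2nc(-c3ccc4ccccc4n3)no2)CC1` gives 480 nM
- compound 3 `COc1ccccc1NC(=O)N1CCC(c2noc(-c3ccc4ccccc4n3)n2)CC1` gives 2400 nM

Compound 2 holds the second highest number of the three. Compound 3 sits above it, with a gap beyond the scatter, and compound 1 sits below it, also by a gap beyond the scatter. Compound 3 also differs from compound 2 in more than one place, so nothing on its own can be read from that pair.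

Compound 4 `O=C(Nc1cccc2cccnc12)N1CCC(c2nc(-c3ccc4ccccc4n3)no2)CC1` has not yet been measured in this assay . Relative to compound 2 the change is quinolin-8-yl in place of 2-isopropylphenyl on an amide-type nitrogen. The rest of the structure, including the shared core, is kept as in compound 2.

Among the compounds with values here, no single-change pair among the measured compounds touches this part of the molecule, so there is no measured step to lean on. The two aryl ureas on this core, compound 2 and compound 3, sit at the weaker end of the set, while only compound 1 reaches a low number. With that in mind, the step from compound 2 to compound 4 in this assay is expected to be small, likely within the scatter, with at most a modest move toward a lower number: a 1.5-fold lower number from compound 2 to compound 4 (0.18 log units; within the scatter).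

For compound 4 the estimate is 320 nM, with a range from 90 nM to 1400 nM.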

Compound 4, half-maximal inhibitory concentration: 1400 nM
Compound 4: the middle estimate sits 4.4-fold (0.64 log units) below what was measured, within the range that was stated.
By their numbers in this assay, from the lowest: compound 1; then compound 2; then compounds 4 and 3 (each within the scatter of the next).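

In this assay, within the data shown here, this is the first single-change step on the urea aryl group of the series: a 2.9-fold higher number from compound 2 to compound 4 (0.46 log units; beyond the scatter), a modest move toward weaker inhibition, but one beyond the scatter. The group on this amide-type nitrogen therefore matters on the shared core of compound 2, and replacing 2-isopropylphenyl with quinolin-8-yl, which adds a ring and a hydrogen-bond acceptor, does not improve the read-out. No measurement at hand bears on the reason for this rise, and this one step cannot separate the loss of the isopropyl group from the gain of the ring nitrogen.

Still open, from the compounds shown here alone, is how a plain phenyl, a 2-tert-butylphenyl or a naphthalen-1-yl would read on the same nitrogen, the last of these keeping the fused carbon ring system without the ring nitrogen of quinolin-8-yl. Also open is whether the cyclohexyl group of compound 1 would carry over to the core of compound 2: the other pairs in the set differ in more than one place, so they cannot be read as steps.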